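The source may report more compounds than this note shows. Statements on the series, on what has been measured and on what is new or still open speak of the compounds shown alone.

Compound 1: `COc1ccc2c(c1)c(C1=CCNCC1)cn2S(=O)(=O)c1cccc2ncccc12` gives 4 nM in an assay on HEK293 cells for displacement of a labelled ligand from 5-hydroxytryptamine receptor 6 (Homo sapiens), read by scintillation counting; a lower number here means a stronger inhibitor, a higher number a weaker inhibitor.
Compound 2: `COc1ccc2c(c1)c(C1=CCNCC1)cn2S(=O)(=O)c1ccc2ncccc2c1` gives 14 nM.
Compound 3: `COc1ccc2c(c1)c(C1=CCNCC1)cn2S(=O)(=O)c1ccc2cccnc2c1` gives 2 nM.

All three share one core and differ only in which position of the quinoline carries the sulfonyl sulfur. Compound 3 has the lowest number of the three, but the gap to compound 1 is within the scatter, while the gap to compound 2 is beyond it.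

Compound 4 is `COc1ccc2c(c1)c(C1=CCNCC1)cn2S(=O)(=O)c1cncc2ccccc12`. Its change from compound 3 is isoquinolin-4-yl in place of quinolin-7-yl on a sulfonyl sulfur; the same atoms are kept, joined differently. The measured steps that bear on this are of the same kind, a move of the ring nitrogen: a 3.5-fold higher number from compound 1 to compound 2 (0.54 log units; beyond the scatter), a 2.0-fold lower number from compound 1 to compound 3 (0.30 log units; within the scatter) and a 7.0-fold lower number from compound 2 to compound 3 (0.85 log units; beyond the scatter). Such moves have ranged from within the scatter to modest, in both directions, so a modest step either way, or none beyond the scatter, is expected here. Compound 4 is therefore estimated at 5 nM, within 1.5 nM to 16 nM, corresponding to an expected step of a 2.5-fold higher number from compound 3 to compound 4 (0.40 log units; beyond the scatter).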

Compound 4, inhibition constant in the 5-hydroxytryptamine receptor 6 assay: 3 nM
The estimate for compound 4 lay 1.7-fold (0.22 log units) above the measured number, within the range that was stated.
By their numbers in the 5-hydroxytryptamine receptor 6 assay, from the lowest: compounds 3, 4 and 1 (each within the scatter of the next); then compound 2.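

In the 5-hydroxytryptamine receptor 6 assay, the isoquinolin-4-yl group on the sulfonyl sulfur gives a 1.5-fold higher number from compound 3 to compound 4 (0.18 log units; within the scatter) and a 1.3-fold lower number from compound 1 to compound 4 (0.12 log units; within the scatter), so compound 4 cannot be told apart from either compound. Among the compounds shown here, this shows that this position accepts an isoquinoline as well as a quinoline, since the earlier compounds varied only the attachment point of a quinoline; compound 2 is the one that goes against this picture, with a 4.7-fold lower number from compound 2 to compound 4 (0.67 log units; beyond the scatter). In a physicochemical assay for solubility, at pH 7.4 (a higher number here means a more soluble compound, a lower number a less soluble compound), compound 3 gives > 5000 ug/mL, which is a limit of the assay and not a number. In the physicochemical assay, compound 4 gives > 5000 ug/mL, which is also a limit of the assay and not a number. In the physicochemical assay, the step from compound 3 to compound 4 cannot be read, as both values are a limit of the assay and not numbers: the limit of > 5000 ug/mL in the physicochemical assay, at which 2 of the 2 values shown sit.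

Going by these compounds, how an amine or a carboxylic acid added to the isoquinolin-4-yl group would change the result in the 5-hydroxytryptamine receptor 6 assay remains open. So does any real difference between compound 3 and compound 4 in the physicochemical assay.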